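Aromatic Methyl Added to Compound 1: What to Expect

The source may report more compounds than this note shows. Statements on the series, on what has been measured and on what is new or still open speak of the compounds shown alone.

Compound 1, `COc1cc(O)c(C=O)c2c1[C@H](O)C[C@@H](c1ccccc1)O2`: 40 nM
Compound 2, `COc1c(C)c(OC)c2c(c1C)O[C@H](c1ccccc1)C[C@H]2O`: 10700 nM
Compound 3, `COc1cc(O)c(C=O)c2c1[C@H](OC)C[C@@H](c1ccccc1)O2`: 90 nM

Of the compounds shown here, three have been measured in an assay on cells for inhibition of Aromatase (Homo sapiens), with a stated time of 30 min; on this read-out higher numbers stand for weaker inhibition and lower numbers for stronger inhibition. Compound 1 gives 40 nM, the lowest of the three numbers. Its nearest neighbour is compound 3, which gives 90 nM in this assay, and the furthest is compound 2, which gives 10700 nM. Among the compounds with values here, the one single-place step measured is a 2.3-fold higher number from compound 1 to compound 3 (0.35 log units; beyond the scatter), a modest rise. Within the data shown here, compound 2 differs from compound 1 in several places at once, so its value shows only that a compound built in that way is far weaker; it cannot be read as a single step.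

Compound 4, `COc1c(C)c(O)c(C=O)c2c1[C@H](O)C[C@@H](c1ccccc1)O2`, differs from compound 1 as follows: methyl in place of hydrogen on an aromatic carbon. Among the measured compounds shown here, no measured step tests a methyl on an aromatic carbon on its own, so the only guide is that the one small change measured so far, the step from compound 1 to compound 3, moved the number modestly. A small step, a 1.5-fold higher number from compound 1 to compound 4 (0.18 log units; within the scatter), is therefore expected, with the direction uncertain and possibly nothing beyond the scatter. Compound 4 is estimated to give 60 nM in this assay, within a range from 20 nM to 200 nM.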

Compound 4, half-maximal inhibitory concentration: 80 nM
Compound 4: the middle estimate sits 1.3-fold (0.12 log units) below what was measured; low and high end bracket the measured number.
By their numbers in this assay, from the lowest: compounds 1, 4 and 3 (each within the scatter of the next, the first and the last beyond it); then compound 2.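

Adding a methyl to this aromatic carbon, ortho to a hydroxy group and ortho to a methoxy group, gives a 2.0-fold higher number from compound 1 to compound 4 (0.30 log units; within the scatter) and so produces no change that can be told apart from repeat-measurement noise. Within the data shown here, this position on the core of compound 1 therefore accepts one extra carbon without a clear cost, which the earlier compounds could not show, as none of them isolated a change at this carbon. Nothing available explains this tolerance.

As far as these compounds go, it remains open whether this carbon would also accept something larger or different, such as an ethyl chain, a chlorine atom or an amine. Also open, from the compounds shown here alone, is how this methyl would combine with the methyl on the oxygen in compound 3, as the two changes appear here only separately.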